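The source may hold more compounds than are shown below. What is called first, only, known or untested is meant among the compounds shown, and "the series" means these compounds.

Compound 3 `CN(C)CCCNc1nc(N(C)C)nc2cc(-c3ccc(C(F)(F)F)cc3)sc12` gives 212 ug/mL in a physicochemical assay for solubility, at pH 2; a lower number here means a less soluble compound, a higher number a more soluble compound. Compound 1 `CNc1nc(NCCN2CCNCC2)c2sc(-c3ccc(C(F)(F)F)cc3)cc2n1` gives 203 ug/mL, a number within the scatter of that of compound 3. Compound 2 `CNc1nc(NC2CCOCC2)c2sc(-c3ccc(C(F)(F)F)cc3)cc2n1` gives < 5 ug/mL, a limit rather than a number. That value sits at the limit of < 5 ug/mL in this assay, at which 1 of the 3 values shown sits. For the measured compounds named here, the only measured step, an at least 40-fold lower number from compound 1 to compound 2 (1.60 log units; beyond the scatter), is large, but it changes a different group from the one changed here. Compound 4 `CN(C)CCCNc1nc(NCc2ccccc2)nc2cc(-c3ccc(C(F)(F)F)cc3)sc12` differs from compound 3 in that (benzylamino in place of dimethylamino on an aromatic carbon). Going by the values given here, no measured step matches this change, so the expectation rests mainly on the (3-(dimethylamino)propyl)amino group that compound 4 keeps from compound 3. A moderately lower number is expected, with the step estimated as a 2.7-fold lower number from compound 3 to compound 4 (0.42 log units; beyond the scatter). Compound 4 is therefore estimated at 80 ug/mL, expected to lie between 20 ug/mL and 250 ug/mL.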

Compound 4, solubility: 208 ug/mL
Estimate against measurement, compound 4: 2.6-fold (0.41 log units) below, within the range that was stated.
By their numbers in this assay, from the lowest: compounds 1, 4 and 3 (each within the scatter of the next). At a limit, below all of these: compound 2.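

In this assay the step of a 1.0-fold lower number from compound 3 to compound 4 (0.01 log units; within the scatter) swaps dimethylamino for benzylamino on the aromatic carbon between two ring nitrogen atoms. This position therefore takes a six-membered aromatic ring and a hydrogen-bond donor, with the (3-(dimethylamino)propyl)amino group kept, and the two numbers cannot be told apart. Nothing measured here gives a reason for this. The compounds shown leave open whether a carboxylic acid or a longer chain at this position would give the same picture. They also leave open what benzylamino gives when oxan-4-yl replaces the (3-(dimethylamino)propyl) chain on the other nitrogen.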